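From Methyl to (Trifluoromethyl)sulfanyl in Compound 3

A few compounds are considered here, and "the series" means these few. Any claim that something is new, unique, unknown or untested is made for them only; others in the source may bear on it.

- Compound 1 `C=C(Br)C(=O)Nc1cccc(/C=C/C(=O)Nc2cccc(F)c2)c1`: 4600 nM
- Compound 2 `C=C(Br)C(=O)Nc1cccc(/C=C/C(=O)Nc2ccc(C)cc2)c1`: 1200 nM

Both values come from a functional assay on HT-29 cells (Homo sapiens) for inhibition, read by MTT assay, with a stated time of 72 h; a lower number here means a stronger inhibitor, a higher number a weaker inhibitor. Compound 2 has the lower of the two numbers, which makes it the stronger inhibitor of this pair. The next compound, compound 3 `C=C(Br)C(=O)Nc1cccc(/C=C/C(=O)Nc2ccc(SC(F)(F)F)cc2)c1`, differs from compound 2 in one group: (trifluoromethyl)sulfanyl in place of methyl on an aromatic carbon, para to a large group ((trifluoromethyl)sulfanyl in place of methyl on an aromatic carbon).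

Among the measured compounds shown here, only one measured step can guide an expectation, and it also involves a change to the aromatic group on the amide-type nitrogen: a 3.8-fold lower number from compound 1 to compound 2 (0.58 log units; beyond the scatter). This step suggests that changes in this part of the molecule can shift the number modestly. However, neither measured compound carries the new group, so the data favour no clear direction. A step no larger than that modest one is therefore expected, and it may not exceed the scatter. The expected change is a 1.2-fold lower number from compound 2 to compound 3 (0.08 log units; within the scatter). For compound 3 the estimated value is 1000 nM, with an expected range from 300 nM to 3500 nM.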

Compound 3, half-maximal inhibitory concentration: 39800 nM
For compound 3 the middle estimate is 40-fold (1.60 log units) below the measured one, outside the stated range (above it).
By their numbers in this assay, from the lowest: compound 2; then compound 1; then compound 3.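

In this assay, replacing methyl with (trifluoromethyl)sulfanyl on an aromatic carbon, para to a large group, gives a 33-fold higher number from compound 2 to compound 3 (1.52 log units; beyond the scatter), making compound 3 a much weaker inhibitor than compound 2. This position is therefore far from indifferent to the group placed on it: the earlier change on the same aromatic group, a 3.8-fold lower number from compound 1 to compound 2 (0.58 log units; beyond the scatter), was only modest and gave no hint that one swap could cost this much. No accompanying measurement bears on this result, so the loss can be stated but not explained.

On these data alone, with only methyl and (trifluoromethyl)sulfanyl to compare at this carbon, it remains open which part of the new group matters, the sulfur or the three fluorines. A methylsulfanyl or a trifluoromethyl group on the same carbon would help separate those two parts, while an amine or a methoxy group would show whether other groups at this position can match methyl or also bring a large loss.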